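This account rests on a few compounds, and the source may have more. Where it says the series, first, only, none or still open, it means among the compounds named here.

Measured compounds:
compound 1 `COc1cc(/C=C/C(=O)c2cccc(-n3cc(-c4ccccc4)[nH]c3=O)c2)ccc1O` gives 2040 nM
compound 2 `O=C(/C=C/c1cccc(O)c1)c1cccc(-n2cc(-c3ccccc3)[nH]c2=O)c1` gives 3350 nM

Both numbers come from a functional assay on K562 cells (Homo sapiens) for inhibition; on this read-out lower numbers stand for stronger inhibition of growth and higher numbers for weaker inhibition of growth. Compound 1 carries the lower of the two numbers, but the step of a 1.6-fold higher number from compound 1 to compound 2 (0.22 log units; within the scatter) lies within the scatter, so the two compounds are not separated by these data.

Compound 3 `COc1ccc(-c2cn(-c3cccc(C(=O)/C=C/c4ccc(O)c(OC)c4)c3)c(=O)[nH]2)cc1` is not yet measured. It differs from compound 1 by methoxy in place of hydrogen on an aromatic carbon; cut one bond further out, the change reads phenyl to 4-methoxyphenyl, on the ring attached to the shared core. Within the data shown here, no measured step touches this ring: the single step on record alters the aryl on the double-bonded chain, and it stays within the scatter. Nothing in the series therefore points to a shift beyond the scatter in this assay in either direction for compound 3.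

The estimate for compound 3 in this assay is 2000 nM, with a range of 800 nM to 5000 nM. The step expected from compound 1 is a 1.0-fold lower number from compound 1 to compound 3 (0.01 log units; within the scatter), essentially flat.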

Compound 3, concentration for 50% growth inhibition: 2350 nM
Compound 3: the middle estimate sits 1.2-fold (0.07 log units) below what was measured; the measured number falls inside the stated range.
By their numbers in this assay, from the lowest: compounds 1, 3 and 2 (each within the scatter of the next).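

Among these compounds, the ring attached to the shared core had not been touched by any earlier step, and this is the first reading there. In this assay, methoxy in place of hydrogen on an aromatic carbon, para to a large group, gives a 1.2-fold higher number from compound 1 to compound 3 (0.06 log units; within the scatter), so phenyl and 4-methoxyphenyl are not separated at this position and the added group leaves growth inhibition without a detectable shift. No evidence on hand accounts for this flat result.

A single substituent cannot show whether this carbon is generally insensitive to change, and an amine or a carboxylic acid in place of methoxy could still move the number beyond the scatter. Going by these compounds, whether a longer chain such as butoxy at the same carbon would behave like methoxy also remains open.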